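This account rests on a few compounds, and the source may have more. Where it says the series, first, only, none or still open, it means among the compounds named here.

In a functional assay (plasma) with Oryctolagus cuniculus as the target (a higher number here means a weaker inhibitor, a lower number a stronger inhibitor), two compounds built on the shared core have been measured so far. Compound 1 (`Cc1nc2cnccc2n1CC1CCN(C(=O)CCc2ccccc2)CC1`) gives 60 nM, while compound 2 (`Cc1nc2cnccc2n1CC1CCN(C(=O)CN(C)c2ccccc2)CC1`) gives 23 nM, the lower of the two numbers. Going by the values given here, the only measured step is modest: a 2.6-fold lower number from compound 1 to compound 2 (0.42 log units; beyond the scatter). It puts methyl(phenyl)amino in place of benzyl on a saturated chain carbon bound to a carbonyl carbon.

Compound 3 (`COc1ccccc1N(C)CC(=O)N1CCC(Cn2c(C)nc3cnccc32)CC1`) departs from compound 2 in one place, with methoxy in place of hydrogen on an aromatic carbon, ortho to a large group: methoxy in place of hydrogen on an aromatic carbon. The same difference reads phenyl to 2-methoxyphenyl. The step to compound 2 bears on this only loosely, as it changed the chain and left the aromatic ring unsubstituted. Among the compounds with values here, no measured pair shows what a substituent on that ring does, so the data give no direction for the new step. A shift beyond the scatter remains possible in either direction, but none is expected. The expected step is a 1.2-fold lower number from compound 2 to compound 3 (0.06 log units; within the scatter). For compound 3 the estimated value is 20 nM, with an expected range of 7 nM to 60 nM.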

Compound 3, half-maximal inhibitory concentration: 14 nM
The estimate for compound 3 lay 1.4-fold (0.15 log units) above the measured number, and the stated range covers the measured number.
By their numbers in this assay, from the lowest: compounds 3 and 2 (each within the scatter of the next); then compound 1.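

Going by these compounds alone, compound 3 gives the first reading of a substituent on this aromatic ring in this assay, and the methoxy group, ortho to a large group, produces a step that stays within the scatter: a 1.6-fold lower number from compound 2 to compound 3 (0.22 log units; within the scatter) is what the comparison shows. At this place, then, the ring carries the methoxy group without a change in the number that can be told from repeated measurement, and the phenyl to 2-methoxyphenyl exchange gives no firm gain or loss. The separation from the benzyl compound also holds with the substituted ring, where the exchange for (2-methoxyphenyl)(methyl)amino gives a 4.3-fold lower number from compound 1 to compound 3 (0.63 log units; beyond the scatter) and lies beyond the scatter (no supporting measurement bears on this result).

What the compounds shown leave open is whether this reading is particular to methoxy, since a single group on a single ring carbon says little about a chlorine atom, a hydroxyl group or an ethoxy group in the same place. They also leave open whether methoxy on another carbon of the ring would stay within the scatter of the unsubstituted compound 2.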